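The compounds below may be only part of what the source reports. "The series", "measured", "known", "first", "only" and "open" are said of these compounds alone.

Compound 2 `CC(=O)N[C@@H]1C[C@H]2O[C@@](C)([C@@H]1O)n1c3ccc(O)cc3c3c4c(c5c6ccccc6n2c5c31)C(=O)NC4` carries the highest number of the two compounds measured in a functional assay on HCT-116 cells (Homo sapiens) for cytotoxicity, read by MTT assay, with a stated time of 48 h; on this read-out lower numbers stand for stronger inhibition and higher numbers for weaker inhibition: in this assay compound 2 gives 2700 nM, whereas compound 1 `C[C@]12O[C@H](C[C@@H](N)[C@H]1O)n1c3ccccc3c3c4c(c5c6ccccc6n2c5c31)CNC4=O` gives 200 nM in this assay. Compound 3 `CC(=O)N[C@@H]1C[C@H]2O[C@@](C)([C@@H]1O)n1c3ccccc3c3c4c(c5c6ccccc6n2c5c31)C(=O)NC4` differs from compound 2 by one change (hydrogen in place of hydroxy on an aromatic carbon). For the measured compounds named here, no step between measured compounds is available for this change; the lower number of compound 1, which also lacks the hydroxy, is the only guide. A moderate step toward a lower number is expected in this assay, of size a 3.0-fold lower number from compound 2 to compound 3 (0.48 log units; beyond the scatter). Compound 3 is therefore estimated at 900 nM, within 250 nM to 3000 nM.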

Compound 3, half-maximal inhibitory concentration: 1000 nM
The estimate for compound 3 lay 1.1-fold (0.05 log units) below the measured number; the measured number falls inside the stated range.
By their numbers in this assay, from the lowest: compound 1; then compound 3; then compound 2.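

In this assay, for the compounds shown here, hydrogen in place of hydroxy on an aromatic carbon gives a 2.7-fold lower number from compound 2 to compound 3 (0.43 log units; beyond the scatter), so this position has its own direct reading for the first time, with the acetyl on the amine nitrogen unchanged. Acetyl in place of hydrogen on that nitrogen, with no hydroxy present, gives a 5.0-fold higher number from compound 1 to compound 3 (0.70 log units; beyond the scatter), so each of the two places moves the number beyond the scatter. Nothing given here accounts for either step. From the compounds shown here alone, it remains open how a methoxy or a fluorine at that aromatic carbon would compare with hydrogen and hydroxy. Also open, going by these compounds, is whether a longer acyl chain on the amine nitrogen would shift the number further.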